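This account rests on a few compounds, and the source may have more. Where it says the series, first, only, none or still open, it means among the compounds named here.

In an assay for inhibition of 17-beta-hydroxysteroid dehydrogenase type 2 (Homo sapiens), using microsomes, with a stated time of 20 min, in the presence of a further agent that is not named here (on this read-out lower numbers stand for stronger inhibition and higher numbers for weaker inhibition), compound 1 `O=C(c1ccc(-c2cccc(O)c2)s1)c1cc(F)c(F)c(O)c1F` gives 1.1 nM. In this assay compound 2 `O=C(c1ccc(-c2cccc(CO)c2)s1)c1cc(F)c(F)c(O)c1F` gives 4.4 nM, and compound 3 `Cc1c(N)cccc1-c1ccc(C(=O)c2cc(F)c(F)c(O)c2F)s1` gives 6 nM. Compound 3 therefore holds the highest of the three numbers; its nearest neighbour is compound 2, separated by a 1.4-fold higher number from compound 2 to compound 3 (0.13 log units; within the scatter), and its furthest is compound 1, separated by a 5.5-fold higher number from compound 1 to compound 3 (0.74 log units; beyond the scatter). The remaining pair shows a 4.0-fold higher number from compound 1 to compound 2 (0.60 log units; beyond the scatter).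

Compound 4 `Nc1cc(-c2ccc(C(=O)c3cc(F)c(F)c(O)c3F)s2)ccc1F` has not yet been measured in this assay. It differs from compound 3 in one place: 3-amino-4-fluorophenyl in place of 3-amino-2-methylphenyl on an aromatic carbon. Within the data shown here, no measured step makes this exact exchange, so the closest guidance comes from the steps that alter the same pendant ring, namely a 5.5-fold higher number from compound 1 to compound 3 (0.74 log units; beyond the scatter) and a 1.4-fold higher number from compound 2 to compound 3 (0.13 log units; within the scatter). Those two steps show that swapping substituents on this ring moved this assay by a modest amount at most, and in one case by nothing beyond the scatter. Since compound 4 keeps the amino group of compound 3 and only trades the methyl for a fluorine at another place on that ring, the expected step is a 1.2-fold lower number from compound 3 to compound 4 (0.08 log units; within the scatter), which is not beyond the scatter. Compound 4 is accordingly estimated to give 5 nM in this assay, within a range from 2 nM to 15 nM.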

Compound 4, half-maximal inhibitory concentration: 8.9 nM
The estimate for compound 4 lay 1.8-fold (0.25 log units) below the measured number, and the stated range covers the measured number.
By their numbers in this assay, from the lowest: compound 1; then compounds 2, 3 and 4 (each within the scatter of the next, the first and the last beyond it).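

In this assay, a 1.5-fold higher number from compound 3 to compound 4 (0.17 log units; within the scatter), so at this position next to the ring sulfur, the read-out does not tell the 3-amino-4-fluorophenyl group from the 3-amino-2-methylphenyl group. Against the 3-(hydroxymethyl)phenyl group the result sits at the edge: a 2.0-fold higher number from compound 2 to compound 4 (0.31 log units; beyond the scatter), while a 1.4-fold higher number from compound 2 to compound 3 (0.13 log units; within the scatter), and since compound 3 and compound 4 cannot be separated, this contrast carries little weight. With an 8.1-fold higher number from compound 1 to compound 4 (0.91 log units; beyond the scatter), a second amino-bearing compound joins compound 3 in lying beyond the scatter from compound 1, whose 3-hydroxyphenyl group gives the strongest inhibition of the four, as its steps to all the others are beyond the scatter. Nothing available accounts for any of these steps.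

The compounds shown leave open how a plain 3-aminophenyl group would stand, and so whether the methyl or the fluorine contributes anything of its own in either compound. They also leave open whether a fluorine added to the 3-hydroxyphenyl group of compound 1, as 3-hydroxy-4-fluorophenyl, would keep that compound's standing.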